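Swapping the aryl group on the hydrazone of compound 2

The source may hold more compounds than are shown below. What is called first, only, known or untested is meant among the compounds shown, and "the series" means these compounds.

Measured compounds:
compound 1 `CN(C)CCn1cnnc1-c1cc(Oc2ccc(NC(=O)N/N=C/c3cc(C(C)(C)C)cc(C(C)(C)C)c3O)cc2F)ccn1`, 590 nM
compound 2 `COc1cc(/C=N/NC(=O)Nc2ccc(Oc3ccnc(-c4nncn4CCN(C)C)c3)c(F)c2)cc(OC)c1OC`, 2770 nM
compound 3 `CN(C)CCn1cnnc1-c1cc(Oc2ccc(NC(=O)N/N=C/c3cc(Br)c(O)c(Br)c3)cc2F)ccn1`, 3760 nM

In a functional assay on NCI-H460 cells (Homo sapiens) for cytotoxicity, read by MTT assay, with a stated time of 72 h (on this read-out higher numbers stand for weaker inhibition and lower numbers for stronger inhibition), compound 2 gives 2770 nM, the second highest of the three numbers; compound 3 sits nearest, and compound 1 lies well lower. Among the measured compounds shown here, the one step between measured compounds, a 1.4-fold higher number from compound 2 to compound 3 (0.13 log units; within the scatter), is within the scatter. Compound 4 `CN(C)CCn1cnnc1-c1cc(Oc2ccc(NC(=O)N/N=C/c3ccc(O)cc3O)cc2F)ccn1` has not yet been measured; it differs from compound 2 as follows: 2,4-dihydroxyphenyl in place of 3,4,5-trimethoxyphenyl on a carbon with a double bond to nitrogen. For the measured compounds named here, no measured step involves this group, so the change from compound 2 to compound 3 offers only a loose guide. An unchanged number or a modest rise is expected for compound 4, about 3500 nM (range 1200 nM to 10000 nM), which would mean an estimated 1.3-fold higher number from compound 2 to compound 4 (0.10 log units; within the scatter).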

Compound 4, half-maximal inhibitory concentration: 11300 nM
Compound 4: middle estimate off by 3.2-fold (0.51 log units), on the low side; the whole stated range lies below it.
By their numbers in this assay, from the lowest: compound 1; then compounds 2 and 3 (each within the scatter of the next); then compound 4.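

This position is not indifferent to the aryl group: where the earlier swap stayed within the scatter, 2,4-dihydroxyphenyl gives a 4.1-fold higher number from compound 2 to compound 4 (0.61 log units; beyond the scatter) and a 3.0-fold higher number from compound 3 to compound 4 (0.48 log units; beyond the scatter). So in this assay a change at this carbon can weaken inhibition beyond the scatter, even though the rest of the molecule stays the same. Nothing measured here explains the shift.

From the compounds shown here alone, it remains open whether 2-hydroxyphenyl or 4-hydroxyphenyl alone would behave like 2,4-dihydroxyphenyl. Also open, going by these compounds, is how an aryl ring bearing an amine or a carboxylic acid would read.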